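This account rests on a few compounds, and the source may have more. Where it says the series, first, only, none or still open, it means among the compounds named here.

Compound 1 `Cc1c(Oc2cnc(C(=O)NC(C)CO)cn2)ccc2c1B(O)OC2`: 0.603 L/kg
Compound 2 `Cc1c(Oc2cnc(C(=O)N[C@@H](CO)CC(F)(F)F)cn2)ccc2c1B(O)OC2`: 0.741 L/kg

In an ADME assay on the whole organism (strain CD1) for pharmacokinetics, with Mus musculus as the target, read by LC-MS, at a dose of 5 mg/kg by the intravenous route (a lower number here means that more of the compound stays in the plasma, a higher number that more of the compound sits outside the plasma), compound 2 gives 0.741 L/kg, which lies within the scatter of compound 1 at 0.603 L/kg. Compound 3 `Cc1c(Oc2cnc(C(=O)N3CC(C)(O)C3)cn2)ccc2c1B(O)OC2` has 3-hydroxy-3-methylazetidin-1-yl in place of (3,3,3-trifluoro-1-(hydroxymethyl)propyl)amino on a carbonyl carbon. Among the compounds with values here, only one measured step bears on this change: a 1.2-fold higher number from compound 1 to compound 2 (0.09 log units; within the scatter). It also alters the amide substituent and stays within the scatter. Within the data shown here, no measured compound carries a ring at this place, so the basis is thin. The expected step is a 1.2-fold lower number from compound 2 to compound 3 (0.08 log units; within the scatter), none beyond the scatter. For compound 3 the estimate is 0.62 L/kg, with an expected range from 0.35 L/kg to 1.1 L/kg.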

Compound 3, volume of distribution at steady state: 0.888 L/kg
Compound 3: middle estimate off by 1.4-fold (0.16 log units), on the low side, within the range that was stated.
By their numbers in this assay, from the lowest: compounds 1, 2 and 3 (each within the scatter of the next).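

Across this assay, a four-membered ring can stand on the carbonyl carbon without leaving the scatter of either open-chain amide: the printed steps are a 1.2-fold higher number from compound 2 to compound 3 (0.08 log units; within the scatter) and a 1.5-fold higher number from compound 1 to compound 3 (0.17 log units; within the scatter). The swap to 3-hydroxy-3-methylazetidin-1-yl also removes the defined stereocentre and the fluorines, yet neither step is beyond the scatter. Nothing measured here offers an explanation for these numbers.

On these data alone, all three compounds carry a hydroxyl in this group, so its removal remains untested. Also open, as far as these compounds go, is whether a carboxylic acid or an amine here would give a step beyond the scatter.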